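The compounds below may be only part of what the source reports. "The series", "measured", "known", "first", "only" and "open" are said of these compounds alone.

Within the data shown here, in an ADME assay on BaF3 cells (Mus musculus) for inhibition, read by CellTiter-Glo, with a stated time of 72 h (on this read-out lower numbers stand for stronger inhibition of growth and higher numbers for weaker inhibition of growth), compound 1 `Cc1ccc(NC(=O)c2cccc(C(F)(F)F)c2)cc1N1Cc2cnc(NC3CCCCC3)nc2N(C)C1=O` gives 5220 nM and compound 2 `Cc1ccc(NC(=O)c2cccc(C(F)(F)F)c2)cc1N1Cc2cnc(NC3CC3)nc2N(C)C1=O` gives 5060 nM, so compound 2 stands level with the only other measured compound. Among the measured compounds shown here, the one measured step, a 1.0-fold lower number from compound 1 to compound 2 (0.01 log units; within the scatter), puts cyclopropyl in place of cyclohexyl on a nitrogen on an aromatic ring. Compound 3 `Cc1cc(Nc2ncc3c(n2)N(C)C(=O)N(c2cc(NC(=O)c4cccc(C(F)(F)F)c4)ccc2C)C3)n(C)n1` changes that same group, with 1,3-dimethyl-1H-pyrazol-5-yl in place of cyclopropyl on a nitrogen on an aromatic ring. The earlier step involved no aromatic group, so it is only a loose guide, but it gives no reason to expect a change beyond the scatter in this assay. The expected result is a 1.3-fold lower number from compound 2 to compound 3 (0.10 log units; within the scatter). Compound 3 is estimated at 4000 nM, with a range of 1300 nM to 10000 nM.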

Compound 3, concentration for 50% growth inhibition: 2060 nM
Estimate against measurement, compound 3: 1.9-fold (0.29 log units) above, and the stated range covers the measured number.
By their numbers in this assay, from the lowest: compound 3; then compounds 2 and 1 (each within the scatter of the next).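

The place on this nitrogen turns out to respond in this assay, although the earlier swap of cyclohexyl and cyclopropyl left the number flat: the change to 1,3-dimethyl-1H-pyrazol-5-yl gives a modest step beyond the scatter (a 2.5-fold lower number from compound 2 to compound 3 (0.39 log units; beyond the scatter)), and the step from the cyclohexyl compound is of the same size (a 2.5-fold lower number from compound 1 to compound 3 (0.40 log units; beyond the scatter)). Of the three groups, only this one is aromatic and only this one has hydrogen-bond acceptors. Nothing measured here accounts for the step. The compounds shown leave open whether the step belongs to the aromatic ring, its two nitrogens or its methyl groups. A plain phenyl, or a pyrazole without methyl groups, on the same nitrogen would begin to separate these.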